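The source may report more compounds than this note shows. Statements on the series, on what has been measured and on what is new or still open speak of the compounds shown alone.

Compound 3 `CCCCCCCCCCCCCC(=O)N[C@@H](CCCNC(=N)N)C(=O)Nc1ccn([C@H]2O[C@@H](CO)[C@H](O)[C@H]2O)c(=O)n1` holds the second highest of the three numbers measured in a physicochemical assay for lipophilicity; on this read-out lower numbers stand for lower lipophilicity and higher numbers for higher lipophilicity. In this assay compound 3 gives 0.45, compound 1 `CCCCCCCCCCCCCC(=O)N[C@@H](CCC(=O)O)C(=O)Nc1ccn([C@H]2O[C@@H](CO)[C@H](O)[C@H]2O)c(=O)n1` gives 0.25 and compound 2 `CCCCCCCCCC(=O)N[C@H](C(=O)Nc1ccn([C@H]2O[C@@H](CO)[C@H](O)[C@H]2O)c(=O)n1)C(C)C` gives 0.78. Among the measured compounds shown here, the only single-point step among the measured compounds runs a number 0.20 log units higher from compound 1 to compound 3 (within the scatter), and it concerns the side chain rather than the acyl chain.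

Compound 4 `CCCCCCCCCC(=O)N[C@@H](CCCNC(=N)N)C(=O)Nc1ccn([C@H]2O[C@@H](CO)[C@H](O)[C@H]2O)c(=O)n1` differs from compound 3 by hydrogen in place of butyl on a saturated chain carbon, nine bonds along the chain from a carbonyl carbon. For the measured compounds named here, no measured pair isolates this change: compound 2 carries the same shortened acyl chain as compound 4 but a different side chain, so it differs from compound 3 in two places, and its value can only be set beside that of compound 3 without a computed step. Trimming a saturated chain by four carbons would, as a rule, be expected to give a lower partition coefficient, but the spread seen here between compound 1 and compound 2 is narrow, so the size of the step is uncertain. On that basis the step from compound 3 to compound 4 is expected to be a number 0.95 log units lower from compound 3 to compound 4 (beyond the scatter). Compound 4 is therefore estimated at -0.5, with a range from -1.3 to 0.3.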

Compound 4, partition coefficient: 0.76
Compound 4: the middle estimate sits 1.26 log units below what was measured; the whole stated range lies below it.
By their numbers in this assay, from the lowest: compounds 1 and 3 (each within the scatter of the next); then compounds 4 and 2 (each within the scatter of the next).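

In this assay, hydrogen in place of butyl on a saturated chain carbon, nine bonds along the chain from a carbonyl carbon, gives a number 0.31 log units higher from compound 3 to compound 4 (beyond the scatter), so in this pair, with the side chain held constant, removing butyl does not go with a lower number. With the acyl chain held constant, the change of side chain gives a number 0.02 log units lower from compound 2 to compound 4 (within the scatter), so this pair does not separate the two side chains. Nothing shown here accounts for the direction of the butyl step.

The compounds shown leave open whether hydrogen in place of butyl keeps this direction when the side chain ends in a simple amine or in the carboxylic acid of compound 1. On these data alone, it also remains open how an acyl chain longer than that of compound 3, or shorter than that of compound 4, would stand in this assay, so a single pair gives the only view of chain length with this side chain.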